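A few compounds are considered here, and "the series" means these few. Any claim that something is new, unique, unknown or untested is made for them only; others in the source may bear on it.

Compound 1, with structure `O=C(CCc1ccc(C(F)(F)F)cc1)Nc1ccc2nc(N3CCC(NS(=O)(=O)O)C3)ccc2c1`, was tested in a functional assay on HEK293 cells for activation of melanin-concentrating hormone receptor 1 (Rattus norvegicus), read by inositol phosphate accumulation (on this read-out lower numbers stand for an effect already at smaller amounts and higher numbers for an effect only at larger amounts of compound), where compound 1 gives 50 nM. A second compound, compound 2 with structure `O=C(CCc1ccc(C(F)(F)F)cc1)Nc1ccc2nc(N3CCCC3)ccc2c1`, was measured twice in the same setting: compound 2 gives 320 nM; 320 nM (2 entries). Among the values shown, compound 1 carries the smaller number, and it is the only compound here that is represented by a single number.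

Compound 3, with structure `Nc1ccc2cc(NC(=O)CCc3ccc(C(F)(F)F)cc3)ccc2n1`, has not yet been measured. It differs from compound 1 in one place: amino in place of 3-(sulfoamino)pyrrolidin-1-yl on an aromatic carbon. The larger group that carried two hydrogen-bond donors and three acceptors is exchanged for a single nitrogen atom bearing one donor and one acceptor, on the aromatic carbon next to the ring nitrogen of the shared core.

For the measured compounds named here, no measured pair here makes exactly this exchange, so the expectation rests on the two values shown. Compound 2, which keeps a bare five-membered ring in that place, sits at a higher number than compound 1, and removing the ring altogether seems likely to push the number higher still. The step of a 24-fold higher number from compound 1 to compound 3 (1.38 log units; beyond the scatter) is expected to be a loss well beyond the scatter. Compound 3 is therefore expected to give about 1200 nM, within a range from 250 nM to 6000 nM.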

Compound 3, half-maximal effective concentration: 720 nM
Compound 3: the middle estimate sits 1.7-fold (0.22 log units) above what was measured; the measured number falls inside the stated range.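

In this assay, for the compounds shown here, amino in place of 3-(sulfoamino)pyrrolidin-1-yl on this aromatic carbon brings a 14-fold higher number from compound 1 to compound 3 (1.16 log units; beyond the scatter), the first direct one-place reading of a change at this position, and it is a large step beyond the usual scatter. Compound 3 still gives a number in the nanomolar range, so the ring and its sulfoamino part are not needed for a readable effect here, although the smaller number stays with the larger group of compound 1. The data shown offer no measurement that would explain this shift.

With compound 2 at 320 nM; 320 nM (2 entries) and compound 3 at 720 nM, these few values do not settle how much of the step belongs to the sulfoamino part and how much to the ring that carries it. Also open, going by these compounds, is how a primary amine or a carboxylic acid in place of the sulfoamino part on the five-membered ring would read, or how a dimethylamino group or a piperidine ring would read on the same aromatic carbon.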